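Swapping the styryl arm for a dimethoxyphenyl ring

The source may hold more compounds than are shown below. What is called first, only, known or untested is meant among the compounds shown, and "the series" means these compounds.

Compound 2 `Cc1cc(O)c(C2=NN(c3ccc(S(N)(=O)=O)cc3)C(/C=C/c3ccccc3)C2)cc1Cl` gives 19400 nM in a functional assay on NCI-H522 cells (Homo sapiens) for antiproliferative activity, with a stated time of 48 h (on this read-out lower numbers stand for stronger inhibition of growth and higher numbers for weaker inhibition of growth), the highest of the two numbers seen so far; compound 1 `Cc1cc(O)c(C2=NN(c3ccc(S(N)(=O)=O)cc3)C(c3ccccc3O)C2)cc1Cl` gives 6280 nM. Among the compounds with values here, the one measured step, a 3.1-fold higher number from compound 1 to compound 2 (0.49 log units; beyond the scatter), shows that replacing an aromatic ring with an alkene chain on that saturated ring carbon weakened growth inhibition. Compound 3 `COc1ccc(C2CC(c3cc(Cl)c(C)cc3O)=NN2c2ccc(S(N)(=O)=O)cc2)cc1OC` reverses that kind of change: 3,4-dimethoxyphenyl in place of 2-phenylethenyl on a saturated ring carbon. Because a 3.1-fold higher number from compound 1 to compound 2 (0.49 log units; beyond the scatter) went the other way, a drop is expected, a 2.4-fold lower number from compound 2 to compound 3 (0.38 log units; beyond the scatter). Compound 3 is therefore estimated at 8000 nM, with a range from 3000 nM to 25000 nM.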

Compound 3, concentration for total growth inhibition: 9610 nM
Compound 3: the middle estimate sits 1.2-fold (0.08 log units) below what was measured; the range from low to high includes it.
By their numbers in this assay, from the lowest: compounds 1 and 3 (each within the scatter of the next); then compound 2.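

At this saturated ring carbon, 3,4-dimethoxyphenyl, like 2-hydroxyphenyl before it, gives a lower number than the 2-phenylethenyl arm: a 2.0-fold lower number from compound 2 to compound 3 (0.31 log units; beyond the scatter). The two aromatic rings cannot be told apart, however, as the step between them is a 1.5-fold higher number from compound 1 to compound 3 (0.18 log units; within the scatter), so swapping two hydroxyl-free oxygen groups for one hydroxyl group on that ring shows no clear effect here. No measurement is at hand that explains these numbers. Still open, on these data alone, is whether this carbon needs an aromatic ring at all, and how a morpholine or a carboxylic acid on that ring would compare.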